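A few compounds are considered here, and "the series" means these few. Any claim that something is new, unique, unknown or untested is made for them only; others in the source may bear on it.

Among the measured compounds shown here, in an ADME assay on L929 cells (Mus musculus) for cytotoxicity, read by resazurin assay, with a stated time of 72 h (a higher number here means a weaker inhibitor, a lower number a stronger inhibitor), compound 3 `Cc1cccc(C(=O)/C=C/c2ccc3c(c2)B(O)OC3)c1` gives 8.56 ug/mL as the only number in this small set. Compound 1 `O=C(/C=C/c1ccc2c(c1)B(O)OC2)c1ccco1` shows > 10 ug/mL as a limit and no number. Compound 2 `O=C(/C=C/c1ccc2c(c1)B(O)OC2)c1ccccc1` shows > 10 ug/mL as a limit too. Compound 4 `O=C(/C=C/c1ccc2c(c1)B(O)OC2)c1ccc(Br)cc1` carries 4-bromophenyl in place of 3-methylphenyl on a carbonyl carbon on the shared core. Because of the limit of > 10 ug/mL in this assay, at which 2 of the 3 values shown sit, both measured steps into compound 3 are only floors, namely an at least 1.1-fold lower number from compound 1 to compound 3 (0.06 log units; that floor lies within the scatter) and an at least 1.1-fold lower number from compound 2 to compound 3 (0.06 log units; that floor lies within the scatter) with neither beyond the scatter. The remaining step, a step that the two limits leave unreadable from compound 1 to compound 2, adds no size. Resting on compound 3 at 8.56 ug/mL and these floors, no step beyond the scatter is expected in this assay for this swap. The expected step is a 1.1-fold higher number from compound 3 to compound 4 (0.02 log units; within the scatter) on this estimate. Compound 4 is expected at 9 ug/mL within an estimated range of 4 ug/mL to 20 ug/mL as a working figure.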

Compound 4, half-maximal inhibitory concentration: > 10 ug/mL
Compound 4: a limit, no number; the forecaster's own chance of this, stated with the estimate: 45%; at least 1.1-fold (0.04 log units) between middle value and limit.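

In this assay, the swap to 4-bromophenyl on the carbonyl carbon yields only a floor, an at least 1.1-fold higher number from compound 3 to compound 4 (0.06 log units; that floor lies within the scatter), so this change shows no step beyond the scatter. Among the compounds shown here, compound 4 joins compound 1 and compound 2 at the limit, which leaves compound 3 as the only compound with a number. The steps into compound 4 from compound 1 and compound 2 cannot be read because both ends are limits: the limit of > 10 ug/mL in this assay, at which 3 of the 4 values shown sit.

From the compounds shown here alone, whether an amine or a carboxylic acid on the phenyl group at this carbonyl carbon would give a step beyond the scatter stays open. Going by these compounds, how far compound 1, compound 2 and compound 4 lie past their limit also stays open.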